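This account rests on a few compounds, and the source may have more. Where it says the series, first, only, none or still open, it means among the compounds named here.

Measured in a functional assay on HepG2 cells (Homo sapiens) for cytotoxicity, read by MTT assay, with a stated time of 72 h; on this read-out higher numbers stand for weaker inhibition and lower numbers for stronger inhibition:
compound 1 `CCN(CC)CCCOc1c(OCc2ccccc2)cc(O)c2c(=O)cc(-c3ccccc3)oc12`: 3010 nM
compound 2 `CN1CCN(CCCCOc2c(OCc3ccccc3)cc(O)c3c(=O)cc(-c4ccccc4)oc23)CC1`: 1500 nM

Of the two numbers, compound 2 has the smaller, but the step of a 2.0-fold lower number from compound 1 to compound 2 (0.30 log units; within the scatter) lies within the scatter, so compound 1 and compound 2 are not separated. Compound 3 `CN1CCN(CCCCOc2c(OCc3nc4ccccc4o3)cc(O)c3c(=O)cc(-c4ccccc4)oc23)CC1` differs from compound 2 by 1,3-benzoxazol-2-yl in place of phenyl on a saturated chain carbon bound to an oxygen on an aromatic ring. Among the compounds with values here, the only measured step changes the amine three bonds along the chain from an oxygen on an aromatic ring and gives no guidance on the benzyloxy group, so no shift beyond the scatter is expected in this assay. Compound 3 is therefore estimated at 1700 nM, range 500 nM to 6000 nM. The expected step of a 1.1-fold higher number from compound 2 to compound 3 (0.05 log units; within the scatter) stays within the scatter.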

Compound 3, half-maximal inhibitory concentration: 4110 nM
Compound 3: the middle estimate sits 2.4-fold (0.38 log units) below what was measured; the measured number falls inside the stated range.
By their numbers in this assay, from the lowest: compounds 2, 1 and 3 (each within the scatter of the next, the first and the last beyond it).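

In this assay, within the data shown here, the benzyloxy position is the first place to give a step beyond the scatter: 1,3-benzoxazol-2-yl in place of phenyl gives a 2.7-fold higher number from compound 2 to compound 3 (0.44 log units; beyond the scatter), a modest weakening. Among these compounds, the one amine change stayed within the scatter, so this position responds more clearly than that one, though on a single pair. Nothing available accounts for this step.

Open, on these data alone, is whether pyridin-2-yl or 1,3-benzothiazol-2-yl at this place would behave like phenyl or like 1,3-benzoxazol-2-yl. Also open, as far as these compounds go, is whether the step holds with the diethylamino chain of compound 1.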